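Replacing the Oxolanyl Ring by Cyclopentyl on the Amine

The compounds below may be only part of what the source reports. "The series", "measured", "known", "first", "only" and "open" are said of these compounds alone.

Measured in an assay on CHO cells for displacement of a labelled ligand from adenosine receptor A1 (Homo sapiens), read by scintillation counting, with a stated time of 3 h (a lower number here means a stronger inhibitor, a higher number a weaker inhibitor), so far:
compound 1 `Cn1c(-c2ccc(F)cc2)nc2c(NC3CCCC3)ncnc21`: 6.2 nM
compound 2 `Cc1ccccc1-c1nc2c(NC3CCCC3)ncnc2n1C`: 55 nM
compound 3 `Cn1c(-c2ccccc2)nc2c(NC3CCOC3)ncnc21`: 8 nM

Compound 3 has the second highest of the three numbers. Its nearest neighbour is compound 1, and the gap between the two is within the usual scatter, so they cannot be ranked against each other. Compound 2 is clearly further away, with a number beyond the scatter above that of compound 3.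

Compound 4 `Cn1c(-c2ccccc2)nc2c(NC3CCCC3)ncnc21` differs from compound 3 in one place: cyclopentyl in place of oxolan-3-yl on a nitrogen on an aromatic ring. Among the measured compounds shown here, the only measured step, an 8.9-fold higher number from compound 1 to compound 2 (0.95 log units; beyond the scatter), concerns the aryl group on the shared core, not the group on the amine nitrogen, so it does not speak directly to this change. For the measured compounds named here, no measured pair shows the oxolanyl-to-cyclopentyl exchange on its own. What the data do offer is that compound 1, which carries cyclopentyl, and compound 3, which carries oxolanyl, sit within the scatter of each other, although they also differ in the aryl group. The change from compound 3 to compound 4 is therefore expected to be small, a 1.3-fold lower number from compound 3 to compound 4 (0.12 log units; within the scatter), in either direction. Compound 4 is estimated at 6 nM, with a range from 2 nM to 16 nM.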

Compound 4, inhibition constant: 2.8 nM
Compound 4: middle estimate off by 2.1-fold (0.33 log units), on the high side, and the stated range covers the measured number.
By their numbers in this assay, from the lowest: compound 4; then compounds 1 and 3 (each within the scatter of the next); then compound 2.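

In this assay, the exchange of oxolan-3-yl for cyclopentyl can now be read on its own, with nothing else in the molecule altered, and it gives a 2.9-fold lower number from compound 3 to compound 4 (0.46 log units; beyond the scatter); on this amine nitrogen, then, the ring with only carbon atoms gives the lower number of this pair. Compound 4 also shows what the substituents on the phenyl ring are worth at this amine: taking away the methyl gives a 20-fold lower number from compound 2 to compound 4 (1.29 log units; beyond the scatter), a large step, while taking away the fluoro gives a 2.2-fold lower number from compound 1 to compound 4 (0.35 log units; beyond the scatter), a modest one, and these steps leave compound 4 with the lowest number of the four. No measurement shown here bears on why the numbers move in these ways.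

On these data alone, it remains open whether the gain from cyclopentyl would be the same size with 4-fluorophenyl or 2-methylphenyl on the shared core, since neither aryl group appears here with oxolan-3-yl. The compounds shown also leave open how a smaller cyclopropyl ring, a larger cyclohexyl ring or a piperidine ring on the amine nitrogen would compare with cyclopentyl.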